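This account rests on a few compounds, and the source may have more. Where it says the series, first, only, none or still open, it means among the compounds named here.

Working notes on the series. All compounds share one core, and differ in the aryl group on a carbonyl carbon of the side chain and in the aryl group of the hydrazone arm. In a functional assay on HeLa cells (Homo sapiens) for inhibition, read by MTT assay, with a stated time of 72 h (a lower number here means a stronger inhibitor, a higher number a weaker inhibitor), compound 1 `CN(C(=O)NC(=O)c1ccc(Cl)cc1Cl)c1nc(C(F)(F)F)c(C(=O)N/N=C/c2cccc(C(F)(F)F)c2)s1` gives 9.6 ug/mL. In this assay compound 3 `CN(C(=O)NC(=O)c1ccc(C(F)(F)F)cc1)c1nc(C(F)(F)F)c(C(=O)N/N=C/c2cccc(C(F)(F)F)c2)s1` gives 6.2 ug/mL, and compound 2 `CN(C(=O)NC(=O)c1ccccc1F)c1nc(C(F)(F)F)c(C(=O)N/N=C/c2cc(C(F)(F)F)cc(C(F)(F)F)c2)s1` gives 4.98 ug/mL. Compound 3 thus stands second highest of the three numbers, with compound 2 nearest and compound 1 furthest, both within the scatter. Within the data shown here, the one single-place step measured so far, a 1.5-fold lower number from compound 1 to compound 3 (0.19 log units; within the scatter), changed the aryl group on the carbonyl carbon and stayed within the scatter.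

Compound 4 `CN(C(=O)NC(=O)c1ccccc1F)c1nc(C(F)(F)F)c(C(=O)N/N=C/c2cccc(C(F)(F)F)c2)s1` differs from compound 3 by 2-fluorophenyl in place of 4-(trifluoromethyl)phenyl on a carbonyl carbon. Among the measured compounds shown here, the only measured step at this position, a 1.5-fold lower number from compound 1 to compound 3 (0.19 log units; within the scatter), bears on it and was within the scatter. Compound 2 carries the same 2-fluorophenyl group as compound 4 but a different hydrazone aryl, and its value and that of compound 3 lie within the scatter of each other. No step beyond the scatter is therefore expected in this assay. Compound 4 is expected near 5.5 ug/mL, with a range from 2.5 ug/mL to 12 ug/mL. The estimated step of a 1.1-fold lower number from compound 3 to compound 4 (0.05 log units; within the scatter) is expected to stay within the scatter.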

Compound 4, half-maximal inhibitory concentration: 19.1 ug/mL
The estimate for compound 4 lay 3.5-fold (0.54 log units) below the measured number; the measured number lies above the stated range.
By their numbers in this assay, from the lowest: compounds 2, 3, 1 and 4 (each within the scatter of the next, the first and the last beyond it).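

In this assay, the aryl group on the carbonyl carbon now gives a step beyond the scatter: 2-fluorophenyl in place of 4-(trifluoromethyl)phenyl gives a 3.1-fold higher number from compound 3 to compound 4 (0.49 log units; beyond the scatter), whereas 2-fluorophenyl in place of 2,4-dichlorophenyl gives a 2.0-fold higher number from compound 1 to compound 4 (0.30 log units; within the scatter), so the outcome at this position depends on which aryl groups are compared. The hydrazone arm also gets its first single-place step, and it too lies beyond the scatter: with 2-fluorophenyl held on the carbonyl carbon, hydrogen in place of trifluoromethyl on an aromatic carbon gives a 3.8-fold higher number from compound 2 to compound 4 (0.58 log units; beyond the scatter), so this arm can shift the number in this assay as much as the carbonyl-side aryl group does. No supporting measurement bears on either step, and the reason for them remains unknown.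

Among these compounds, all steps at the carbonyl carbon share the hydrazone aryl of compound 3, and the only hydrazone step carries 2-fluorophenyl, so it remains open whether either step holds when the other aryl group is changed. Also open, going by these compounds, is how an aryl group bearing an amine or a carboxylic acid would read on the carbonyl carbon.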